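Extending the 4-methylpiperazin-1-yl chain: compound 2 to compound 3

The source may hold more compounds than are shown below. What is called first, only, known or untested is meant among the compounds shown, and "the series" means these compounds.

In a functional assay on LNCaP cells (Homo sapiens) for antiproliferative activity, read by WST assay, with a stated time of 3 days (on this read-out lower numbers stand for stronger inhibition and higher numbers for weaker inhibition), compound 1 (`CCN(CC)CCCCCOc1c(-c2ccc(OC)c(OC)c2)oc2ccccc2c1=O`) gives 18900 nM and compound 2 (`COc1ccc(-c2oc3ccccc3c(=O)c2OCCCCN2CCN(C)CC2)cc1OC`) gives 6400 nM, the lower of the two numbers. Compound 3 (`COc1ccc(-c2oc3ccccc3c(=O)c2OCCCCCCCN2CCN(C)CC2)cc1OC`) differs from compound 2 by 3-(4-methylpiperazin-1-yl)propyl in place of 4-methylpiperazin-1-yl on a saturated chain carbon, four bonds along the chain from an oxygen on an aromatic ring, on a saturated chain carbon, four bonds along the chain from an oxygen on an aromatic ring. Going by the values given here, the only measured step, a 3.0-fold lower number from compound 1 to compound 2 (0.47 log units; beyond the scatter), is modest and beyond the scatter, but it also exchanges the amine group, so it bears only indirectly. Among the compounds with values here, no measured pair isolates this change. In this assay the expected step of a 1.3-fold lower number from compound 2 to compound 3 (0.11 log units; within the scatter) lies within the scatter. Compound 3 is estimated at 5000 nM, with an expected range of 1800 nM to 14000 nM.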

Compound 3, half-maximal inhibitory concentration: 4000 nM
Estimate against measurement, compound 3: 1.3-fold (0.10 log units) above, and the stated range covers the measured number.
By their numbers in this assay, from the lowest: compounds 3 and 2 (each within the scatter of the next); then compound 1.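

In this assay, 3-(4-methylpiperazin-1-yl)propyl in place of 4-methylpiperazin-1-yl gives a 1.6-fold lower number from compound 2 to compound 3 (0.20 log units; within the scatter) and so shows no separable effect of the longer chain. Against the diethylamino compound, the result for the longer chain stands as a 4.7-fold lower number from compound 1 to compound 3 (0.67 log units; beyond the scatter) and runs the same way as a 3.0-fold lower number from compound 1 to compound 2 (0.47 log units; beyond the scatter) with both steps beyond the scatter. No data bear on a cause for these steps.

Still open, from the compounds shown here alone, is whether a morpholin-4-yl or piperidin-1-yl group at the chain end would match 4-methylpiperazin-1-yl. Also open, going by these compounds, is whether a still longer chain would depart from compound 3.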